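The compounds below may be only part of what the source reports. "The series", "measured", "known", "first", "only" and "open" are said of these compounds alone.

Measured so far:
Compound 1, `CCOC[C@H](Oc1ncnc2c1cnn2-c1ncccc1Cl)C(=O)Nc1ccccn1`, gives 2.1 in a physicochemical assay for lipophilicity; on this read-out higher numbers stand for higher lipophilicity and lower numbers for lower lipophilicity.
Compound 2, `Cc1ccc(NC(=O)[C@H](COC(C)C)Oc2ncnc3c2cnn3-c2ccccc2Cl)nc1`, gives 3.9 in this assay.

Of the two numbers measured, compound 1 stands lowest in this assay; its nearest neighbour is compound 2, which stands higher by a gap beyond the usual scatter. Among the measured compounds shown here, no single-point step between these two measured compounds is available, so the two values show only that compound 1 is the lower of the pair.

Compound 3, `CCOC[C@H](Oc1ncnc2c1cnn2-c1ncccc1Cl)C(=O)Nc1ccc(Cl)cn1`, has not yet been measured in this assay. It differs from compound 1 in one place: chloro in place of hydrogen on an aromatic carbon. For the measured compounds named here, since no step between measured compounds bears on this kind of change, the expectation rests on the change itself. A step of moderate size, upward and beyond the scatter, is expected a number 0.70 log units higher from compound 1 to compound 3 (beyond the scatter). Compound 3 is therefore estimated at 2.8 in this assay, in a range from 2.4 to 3.2.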

Compound 3, distribution coefficient: 3
The estimate for compound 3 lay 0.20 log units below the measured number, and the stated range covers the measured number.
By their numbers in this assay, from the lowest: compound 1; then compound 3; then compound 2.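

In this assay, the change from (pyridin-2-yl)carbamoyl to (5-chloropyridin-2-yl)carbamoyl gives a number 0.90 log units higher from compound 1 to compound 3 (beyond the scatter). Among the compounds shown here, this is the first single-place step, and it shows that the read-out responds to a change at this position, two atoms from the ring nitrogen and para to a large group. Nothing available accounts for the size of this step.

For the compounds shown here, the single step cannot show whether chloro would give a similar change at another carbon of this ring or on a different side chain. It also leaves open how fluoro, methoxy, a nitrile or an amine at this same place would compare with chloro.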